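Swapping a saturated ring for an aromatic one on the core

The source may report more compounds than this note shows. Statements on the series, on what has been measured and on what is new or still open speak of the compounds shown alone.

Compound 1 `COc1cc(N(C)CCCO)ccc1/C=C1\C(=O)N(C2CCCCC2)C(=S)N1C` and compound 2 `COc1cc(N(C)CCCO)ccc1/C=C1\C(=O)N(c2ccccc2)C(=S)N1C` share a core; in an assay on isolated protein for inhibition of NADPH oxidase 2 (Homo sapiens), read by chemiluminescence, in the presence of a further agent that is not named here (a higher number here means a weaker inhibitor, a lower number a stronger inhibitor), compound 1 gives 990 nM, and compound 2 gives 2790 nM. The change between them is phenyl in place of cyclohexyl on an amide-type nitrogen in a ring and it made a step of a 2.8-fold higher number from compound 1 to compound 2 (0.45 log units; beyond the scatter). Compound 3 `CCN(CC)c1ccc(/C=C2\C(=O)N(C3CCCCC3)C(=S)N2C)c(O)c1` carries a different core, and the difference between the two cores is not broken down here; in this assay compound 3 gives 1660 nM. Compound 4 `CCN(CC)c1ccc(/C=C2\C(=O)N(c3ccccc3)C(=S)N2C)c(O)c1` is not yet measured. It differs from compound 3 by phenyl in place of cyclohexyl on an amide-type nitrogen in a ring, the same change as before, at the same place. Because compound 1 and compound 2 showed a 2.8-fold higher number from compound 1 to compound 2 (0.45 log units; beyond the scatter), a similar step is expected here, namely a 2.8-fold higher number from compound 3 to compound 4 (0.44 log units; beyond the scatter). On that basis compound 4 is estimated at 4600 nM in this assay.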

Compound 4, half-maximal inhibitory concentration: 910 nM
Compound 4: the middle estimate sits 5.1-fold (0.70 log units) above what was measured, and the stated range ends above it.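

In this assay, putting phenyl in place of cyclohexyl on the core of compound 3 gives a 1.8-fold lower number from compound 3 to compound 4 (0.26 log units; within the scatter), so here the change has no effect that can be told apart from the usual scatter. The effect of this change therefore did not carry over from one core to the other: the same change on two cores in this assay, a 2.8-fold higher number (0.45 log units; beyond the scatter) from compound 1 to compound 2 and a 1.8-fold lower number (0.26 log units; within the scatter) from compound 3 to compound 4, 5.1-fold (0.71 log units) apart, beyond the scatter of two such steps This shows that a step seen on one core cannot safely be assumed on the other, but it does not show why the two cores differ, and two pairs give no rule for any further core.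

The compounds shown leave open which of the differences between the two cores matters. Going by these compounds, how a benzyl group or a short chain carrying an amine would behave on that same nitrogen also remains open.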